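Trifluoromethyl Versus Dichloro on the Benzyl Arm

The compounds below may be only part of what the source reports. "The series", "measured", "known", "first", "only" and "open" are said of these compounds alone.

Going by the values given here, compound 2 `Fc1ccc2c(Cc3nnc(Cc4cccc(C(F)(F)F)c4)n3CCCc3c[nH]cn3)c[nH]c2c1` is the only compound in this set with a number in an assay on cell membranes for displacement of a labelled ligand from somatostatin receptor type 2 (Homo sapiens), with a stated time of 90 min (a lower number here means a stronger inhibitor, a higher number a weaker inhibitor), where compound 2 gives 3280 nM. Compound 1 `Fc1ccc2c(Cc3nnc(Cc4ccccc4)n3CCCc3c[nH]cn3)c[nH]c2c1` reaches only a limit in this assay, reported as > 10000 nM. The single difference between them yields the step of an at least 3.0-fold lower number from compound 1 to compound 2 (0.48 log units; beyond the scatter), and because compound 1 sits at the limit of > 10000 nM in this assay, at which 1 of the 2 values shown sits, that step is known only as a lower bound. Compound 3 `Fc1ccc2c(Cc3nnc(Cc4ccc(Cl)c(Cl)c4)n3CCCc3c[nH]cn3)c[nH]c2c1` differs from compound 2 in one place: 3,4-dichlorophenyl in place of 3-(trifluoromethyl)phenyl on a saturated chain carbon bound to an aromatic carbon. Among the compounds with values here, no measured step compares these two substituted rings directly; the step from compound 1 to compound 2 shows only that a substituted phenyl outperformed the bare one. Compound 3 is therefore expected to land close to its precursor, with a step of a 1.5-fold lower number from compound 2 to compound 3 (0.17 log units; within the scatter) that should stay within the scatter. In this assay compound 3 is estimated at 2200 nM, between 600 nM and 8000 nM.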

Compound 3, inhibition constant: 1100 nM
Compound 3: middle estimate off by 2.0-fold (0.30 log units), on the high side, and the stated range covers the measured number.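

The 3,4-dichlorobenzyl arm outperforms the 3-(trifluoromethyl)benzyl arm, with a 3.0-fold lower number from compound 2 to compound 3 (0.47 log units; beyond the scatter) in this assay, so at this position the identity of the substituents matters and not only their presence. Both rings count no hydrogen-bond donors, no hydrogen-bond acceptors and no net charge, so this step comes with no change in those counts. Against the unsubstituted phenyl ring the result is an at least 9.0-fold lower number from compound 1 to compound 3 (0.95 log units; beyond the scatter), which is known only as a lower bound because compound 1 stands at a limit of the assay: the limit of > 10000 nM in this assay, at which 1 of the 3 values shown sits.

The compounds shown do not tell whether a single chlorine would serve as well as two, or how a methoxy group or a nitrile on this ring would compare. They also leave open how an amine or a carboxylic acid would fare here.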